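The source may report more compounds than this note shows. Statements on the series, on what has been measured and on what is new or still open speak of the compounds shown alone.

Values in an in vitro ADME assay on microsomes from liver (Mus musculus) for pharmacokinetics, read by LC-MS, with a stated time of 10 min, tested at 1 uM; on this read-out higher numbers stand for fast clearance and lower numbers for slow clearance:
compound 1 `CCN1C[C@H](C(=O)Nc2ccc(Cl)cc2)[C@@H](c2ccc(/C=C/C(=O)Nc3ccccc3N)cc2)C1`: 35 mL/min/kg
compound 2 `CCNC(=O)N1C[C@H](C(=O)Nc2ccc(Cl)cc2)[C@@H](c2ccc(/C=C/C(=O)Nc3ccccc3N)cc2)C1`: 25 mL/min/kg

Compound 2, at 25 mL/min/kg, sits within the scatter of compound 1, so these numbers cannot separate the two. The next structure is compound 3 `Nc1ccccc1NC(=O)/C=C/c1ccc([C@H]2CN(c3ncccn3)C[C@@H]2C(=O)Nc2ccc(Cl)cc2)cc1`. In it, pyrimidin-2-yl stands in place of ethylcarbamoyl on an amine nitrogen in a ring: pyrimidin-2-yl in place of ethylcarbamoyl on an amine nitrogen in a ring. The rest of the molecule stays the same.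

Going by the values given here, only one measured step bears on this change: a 1.4-fold lower number from compound 1 to compound 2 (0.15 log units; within the scatter), with ethylcarbamoyl in place of ethyl on that nitrogen. This step is small and does not rise above the scatter of repeated measurements. Among the compounds with values here, a single pair is thin evidence, however, and no measured compound carries an aromatic ring on this nitrogen. The data therefore argue for no direction, and no shift beyond the scatter is expected. The estimated change is a 1.2-fold higher number from compound 2 to compound 3 (0.08 log units; within the scatter). In this assay, compound 3 is expected at 30 mL/min/kg, with an estimated range from 14 mL/min/kg to 60 mL/min/kg.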

Compound 3, clearance: 44 mL/min/kg
The estimate for compound 3 lay 1.5-fold (0.17 log units) below the measured number, within the range that was stated.
By their numbers in this assay, from the lowest: compounds 2, 1 and 3 (each within the scatter of the next).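

In this assay, pyrimidin-2-yl in place of ethylcarbamoyl gives a 1.8-fold higher number from compound 2 to compound 3 (0.25 log units; within the scatter) and pyrimidin-2-yl in place of ethyl gives a 1.3-fold higher number from compound 1 to compound 3 (0.10 log units; within the scatter) on the same amine nitrogen in the ring. Compound 3 is the only one of the three with an aromatic ring on this nitrogen, and even this larger change of group, from a chain to a six-membered aromatic ring with 2 hetero atoms, stays within the scatter of repeated measurements against both neighbours. So ethyl, ethylcarbamoyl and pyrimidin-2-yl cannot be separated by clearance in these compounds, and no information is available on why the numbers fall as they do.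

These three groups do not show whether any group on this nitrogen can move the clearance beyond the scatter. A plain phenyl ring, a longer chain, a chain ending in a carboxylic acid or the bare ring nitrogen carrying only hydrogen could each test this, and any such result would still apply only to this nitrogen of the shared core.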